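Adding an Amino Group to Compound 2

This account rests on a few compounds, and the source may have more. Where it says the series, first, only, none or still open, it means among the compounds named here.

Among the measured compounds shown here, in a functional assay on the whole organism with Mus musculus as the target (a lower number here means that less compound is needed, a higher number that more compound is needed for the effect), compound 2 `COc1cc2c(cc1OC)C(c1ccccc1)=NNC(=O)C2` gives 215 umol/kg, the higher of the two numbers so far. Compound 1 `COc1cc2c(cc1OC)C(c1ccc(N)cc1)=NN=C(S)C2` gives 46.1 umol/kg, a gap beyond the scatter. Compound 3 `COc1cc2c(cc1OC)C(c1ccc(N)cc1)=NNC(=O)C2` changes compound 2 by placing amino in place of hydrogen on an aromatic carbon, turning phenyl into 4-aminophenyl. Compound 1 also carries 4-aminophenyl, although the rest of its structure differs, and the expectation rests on its value of 46.1 umol/kg. The expected change is a fall beyond the scatter, with an estimated step of a 3.1-fold lower number from compound 2 to compound 3 (0.49 log units; beyond the scatter). For compound 3 the estimate is 70 umol/kg, with an expected range from 30 umol/kg to 160 umol/kg.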

Compound 3, dose for half-maximal effect: 65.4 umol/kg
Estimate against measurement, compound 3: 1.1-fold (0.03 log units) above, and the stated range covers the measured number.
By their numbers in this assay, from the lowest: compounds 1 and 3 (each within the scatter of the next); then compound 2.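

Compound 2 and compound 3 differ in one place only, so the change from phenyl to 4-aminophenyl can now be read on its own in this assay: a 3.3-fold lower number from compound 2 to compound 3 (0.52 log units; beyond the scatter). The earlier pair differed in more than one place and could not isolate this step. Nothing available here bears on why the number falls.

Open, from the compounds shown here alone, is whether amino is special at this position, or whether a hydroxyl, a methoxy or a dimethylamino group there would give a similar step. Also open, going by these compounds, is whether amino elsewhere on this ring would do the same.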